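Replacing a Pentyl with Hydrogen on Compound 2

The compounds below may be only part of what the source reports. "The series", "measured", "known", "first", "only" and "open" are said of these compounds alone.

Measured in a toxicity assay on MRC5 cells (Homo sapiens) for inhibition, read by MTT assay, with a stated time of 72 h; on this read-out lower numbers stand for stronger inhibition and higher numbers for weaker inhibition:
Compound 1 `CCCC(=O)OCCc1ccc(O)c(O)c1`: 71500 nM
Compound 2 `CCCCCCCCCCCCCCCC(=O)OCCc1ccc(O)c(O)c1`: > 50000 nM, a limit

Compound 2 has no exact number in this assay. Its result of > 50000 nM is a limit of the assay.

Compound 3 `CCCCCCCCCCC(=O)OCCc1ccc(O)c(O)c1` has not yet been measured. It differs from compound 2 by a single change, hydrogen in place of pentyl on a saturated chain carbon, ten or more bonds along the chain from a carbonyl carbon.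

Within the data shown here, no measured pair shows what such a change does here. Among the measured compounds shown here, the only exact reading is that of compound 1, at 71500 nM, so a modest move toward stronger inhibition is expected rather than a large one. The estimated step of an at least 1.2-fold lower number from compound 2 to compound 3 (0.09 log units; that floor lies within the scatter) may not exceed the usual scatter. For compound 3 the estimated value is 40000 nM, with an expected range from 15000 nM to 100000 nM.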

Compound 3, half-maximal inhibitory concentration: > 50000 nM
Compound 3: only a limit was reported; the forecaster's own chance of this, stated with the estimate: 35%; middle value at least 1.2-fold (0.09 log units) away from the limit.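

In this assay, compound 3 gives > 50000 nM, which is a limit, so neither its step from compound 2 nor its step from compound 1 can be read. The compounds shown leave open whether hydrogen in place of pentyl changes inhibition at all.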